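Benzylic amine to imidazole in the sulfonamide series

The compounds below may be only part of what the source reports. "The series", "measured", "known", "first", "only" and "open" are said of these compounds alone.

Compound 3 `COc1ncc(-c2ccc3nccc(-c4ccc(CN5CCN(C(C)C)CC5)cc4)c3c2)cc1NS(=O)(=O)c1ccc(F)cc1F` stands second highest of the three numbers in a functional assay on HCT-116 cells (Homo sapiens) for cytotoxicity, read by MTT assay, with a stated time of 72 h (on this read-out lower numbers stand for stronger inhibition and higher numbers for weaker inhibition), at 24.7 nM. Its nearest neighbour is compound 2 `COc1ncc(-c2ccc3nccc(-c4ccc(CN5CCCC5)cc4)c3c2)cc1NS(=O)(=O)c1ccc(F)cc1F`, which gives 18.8 nM; the step of a 1.3-fold higher number from compound 2 to compound 3 (0.12 log units; within the scatter). Furthest off is compound 1 `COc1ncc(-c2ccc3nccc(N4CCCC4)c3c2)cc1NS(=O)(=O)c1ccc(F)cc1F` with 3320 nM, and the step of a 180-fold lower number from compound 1 to compound 2 (2.25 log units; beyond the scatter). Compound 4 `COc1ncc(-c2ccc3nccc(-c4ccc(Cn5ccnc5)cc4)c3c2)cc1NS(=O)(=O)c1ccc(F)cc1F` differs from compound 3 by 1H-imidazol-1-yl in place of 4-isopropylpiperazin-1-yl on a saturated chain carbon bound to an aromatic carbon. Among the measured compounds shown here, only the step from compound 2 to compound 3 bears on this place, and it stayed within the scatter; no measured compound carries an aromatic ring on that chain carbon. A small step is therefore expected for compound 4, a 1.4-fold higher number from compound 3 to compound 4 (0.15 log units; within the scatter), with wide uncertainty. Compound 4 is estimated at 35 nM, range 12 nM to 120 nM.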

Compound 4, half-maximal inhibitory concentration: 32.6 nM
Estimate against measurement, compound 4: 1.1-fold (0.03 log units) above; the range from low to high includes it.
By their numbers in this assay, from the lowest: compounds 2, 3 and 4 (each within the scatter of the next); then compound 1.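

At the saturated chain carbon, the five-membered aromatic 1H-imidazol-1-yl stands within the scatter of both saturated rings in this assay: a 1.3-fold higher number from compound 3 to compound 4 (0.12 log units; within the scatter) and a 1.7-fold higher number from compound 2 to compound 4 (0.24 log units; within the scatter). The large step seen earlier for a substituted phenyl in place of pyrrolidin-1-yl on the aromatic carbon recurs with this ring, a 100-fold lower number from compound 1 to compound 4 (2.01 log units; beyond the scatter). Nothing available explains why these groups read alike.

Still open, going by these compounds, is whether a carboxylic acid or a hydroxyl on the chain carbon would read the same. Also open, on these data alone, is whether a longer chain carrying the 1H-imidazol-1-yl would do so.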